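Fluoro in place of methoxy on compound 1

This account rests on a few compounds, and the source may have more. Where it says the series, first, only, none or still open, it means among the compounds named here.

Compound 1 `C/C=C/C(=O)N(Cc1ccc(OC)c(OC)c1)c1cc(OC)c(OC)c(OC)c1`: 32800 nM
Compound 2 `COc1ccc(N(Cc2cc(OC)c(OC)c(OC)c2)C(=O)CN=[N+]=[N-])cc1O`: 38800 nM

Of the compounds shown here, two have been measured so far in a functional assay on HCT-116 cells (Homo sapiens) for inhibition, read by MTT assay, with a stated time of 48 h; on this read-out lower numbers stand for stronger inhibition and higher numbers for weaker inhibition. Compound 1 gives 32800 nM there, and compound 2 gives 38800 nM. Going by the values given here, these two values lie within the usual scatter of each other, so neither compound can be ranked over the other, and compound 1 stands level with the only other number available.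

The next compound, compound 3 `C/C=C/C(=O)N(Cc1ccc(OC)c(F)c1)c1cc(OC)c(OC)c(OC)c1`, keeps the core of compound 1 but carries fluoro in place of methoxy on an aromatic carbon, ortho to a methoxy group and meta to a large group (fluoro in place of methoxy on an aromatic carbon). Among the compounds with values here, no measured pair differing in one place is available, so the data offer no direct guide to this exchange. The expectation therefore rests on compound 1 at 32800 nM alone, and no step beyond the scatter is expected. The estimated step is a 1.2-fold lower number from compound 1 to compound 3 (0.07 log units; within the scatter), with no firm direction. For compound 3 the expected value is 28000 nM, within an estimated range from 11000 nM to 70000 nM.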

Compound 3, half-maximal inhibitory concentration: 1160 nM
Compound 3: middle estimate off by 24-fold (1.38 log units), on the high side, outside the stated range (below it).
By their numbers in this assay, from the lowest: compound 3; then compounds 1 and 2 (each within the scatter of the next).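

In this assay, putting fluoro in place of methoxy on an aromatic carbon, ortho to a methoxy group and meta to a large group, gives a 28-fold lower number from compound 1 to compound 3 (1.45 log units; beyond the scatter), a large step from one exchange at one place. Going by these compounds alone, the earlier numbers could not be ranked and included no pair differing in one place, so this is the first sign that the read-out responds strongly to a single change, and that this position on the six-membered aromatic ring matters. The exchange takes away one hydrogen-bond acceptor and one heavy atom overall, but nothing measured here says what lies behind the step.

The compounds shown leave open whether fluoro itself is needed or whether losing the methoxy is enough, a question that a plain hydrogen, a chloro or a hydroxy group on this same carbon could address. They also leave open whether fluoro in place of methoxy gives a step of similar size on the other methoxy-bearing carbons of compound 1, or only at this one.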